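This account rests on a few compounds, and the source may have more. Where it says the series, first, only, none or still open, it means among the compounds named here.

Measured compounds:
compound 1, `CC1=C(C(=O)OC(C)C)C(C2CCCC2)N/C(=N/C#N)N1`, giving 3% in an assay on cells for displacement of a labelled ligand from adenosine receptor A1 (Homo sapiens), with a stated time of 60 min, tested at 1 uM; on this read-out lower numbers stand for less inhibition and higher numbers for more inhibition at the one concentration tested (going by the name of the read-out)
compound 2, `CCOC(=O)C1=C(C)N/C(=N\C#N)NC1C1CCCC1`, giving 11% in this assay

On the raw figures compound 1 sits at the bottom of this pair, but the step of a number 8 percentage points higher from compound 1 to compound 2 (within the scatter) lies within the scatter, so the two compounds cannot really be separated; both show little inhibition at the single concentration tested.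

Compound 3, `CC1=C(C(=O)OC(C)C)C(c2ccco2)N/C(=N/C#N)N1`, has not yet been measured. It differs from compound 1 in one place: furan-2-yl in place of cyclopentyl on a saturated ring carbon. Going by the values given here, the only measured step, a number 8 percentage points higher from compound 1 to compound 2 (within the scatter), concerns the ester group, where hydrogen replaced methyl, and so does not touch the saturated ring carbon where the new group enters. Among the compounds with values here, there is therefore no measured step that bears on this change, and nothing to suggest a move beyond the scatter in either direction.

Compound 3 is accordingly expected to stay close to compound 1, a step of about a number 3 percentage points higher from compound 1 to compound 3 (within the scatter). The estimate for compound 3 is 6%, with a range from -5% to 20%.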

Compound 3, a percentage reported as inhibition, at one concentration (the size of the read-out at that concentration, not a potency): 21%
Compound 3: middle estimate off by 15 percentage points, on the low side, outside the stated range (above it).
By their numbers in this assay, from the lowest: compounds 1, 2 and 3 (each within the scatter of the next, the first and the last beyond it).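

Within this assay, the saturated ring carbon that bears the cyclopentyl group proves sensitive to what sits on it: furan-2-yl in place of cyclopentyl gives a number 18 percentage points higher from compound 1 to compound 3 (beyond the scatter) and so makes the first step in this set that clears the usual scatter. The two groups have the same count of heavy atoms and both are five-membered rings, but the entering group is aromatic and holds an oxygen counted as a hydrogen-bond acceptor, so a swap of ring type alone, with the size of the group unchanged, is enough to shift the read-out modestly. Nothing available here explains why the furan-2-yl group goes with the higher number.

The compounds shown leave open whether the aromatic ring or its oxygen goes with this shift, and a phenyl group or a thiophene ring on the same carbon would help to tell those two apart. They also leave open whether furan-2-yl would give a similar step alongside the ethyl ester of compound 2 rather than the isopropyl ester of compound 1.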